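The source may hold more compounds than are shown below. What is called first, only, known or untested is meant among the compounds shown, and "the series" means these compounds.

In an ADME assay on the whole organism (plasma) for metabolic stability, with Rattus norvegicus as the target (on this read-out higher numbers stand for a longer-lived compound and lower numbers for a shorter-lived compound), compound 1 `COC(=O)c1cc(C(=CCCCc2ccccc2)c2cc(Br)c(OC)c(C(=O)OC)c2)cc(Br)c1OC` gives 0.917 h, while compound 3 `CCCOC(=O)CCCC=C(c1cc(Br)c(OC)c(C(=O)OC)c1)c1cc(Br)c(OC)c(C(=O)OC)c1` gives 0.0567 h. These two differ in a single place, (propoxycarbonyl in place of phenyl on a saturated chain carbon, three bonds along the chain from a double-bonded chain carbon), and that change brought a 16-fold lower number from compound 1 to compound 3 (1.21 log units; beyond the scatter). Compound 2 `COC(=O)c1cc(C(=CCCCc2ccccc2)c2cc(Cl)c(OC)c(C(=O)OC)c2)cc(Cl)c1OC` gives 1.28 h in this assay; how its core differs from the core of compound 1 is not broken down here. Compound 4 `CCCOC(=O)CCCC=C(c1cc(Cl)c(OC)c(C(=O)OC)c1)c1cc(Cl)c(OC)c(C(=O)OC)c1` has not yet been measured in this assay. It differs from compound 2 by propoxycarbonyl in place of phenyl on a saturated chain carbon, three bonds along the chain from a double-bonded chain carbon, the same change as that between compound 1 and compound 3, at the same place. Because the earlier step of a 16-fold lower number from compound 1 to compound 3 (1.21 log units; beyond the scatter) was large and well beyond the scatter, a step of similar size is expected here, a 16-fold lower number from compound 2 to compound 4 (1.20 log units; beyond the scatter). Compound 4 is therefore estimated at 0.08 h, with an expected range from 0.03 h to 0.2 h.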

Compound 4, half-life: 0.123 h
Compound 4: the middle estimate sits 1.5-fold (0.19 log units) below what was measured; low and high end bracket the measured number.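

Putting propoxycarbonyl in place of phenyl gave a 10-fold lower number from compound 2 to compound 4 (1.02 log units; beyond the scatter) in this assay. Set beside the earlier step, the change carried over from one core to the other with much the same size: the same change on two cores in this assay, a 16-fold lower number (1.21 log units; beyond the scatter) from compound 1 to compound 3 and a 10-fold lower number (1.02 log units; beyond the scatter) from compound 2 to compound 4, 1.6-fold (0.19 log units) apart, within the scatter of two such steps

This shows that, for these two pairs, the size of the drop can be carried across the two cores. It does not show why the half-life falls, nor that the same step would appear on any third core.

What the compounds shown leave open is how a carboxylic acid or an amide would behave in the place of propoxycarbonyl. They also leave open whether a longer or shorter ester would give a step of similar size.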